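The compounds below may be only part of what the source reports. "The series", "measured", "known", "first", "only" and "open" are said of these compounds alone.

Measured so far:
compound 1 `N#C/C(=C\c1c(F)c(F)c(F)c(F)c1F)C(=O)c1c[nH]c2ccccc12` — 14000 nM
compound 2 `COc1ccc(CNC(=O)/C(C#N)=C/c2ccc[nH]2)cc1` — > 50000 nM (a limit of the assay, not a number)
compound 3 `COc1ccc(CNC(=O)/C(C#N)=C/c2ccc(Cl)o2)cc1` — 13000 nM

In a functional assay on SJ-G2 cells (Homo sapiens) for inhibition, read by MTT assay, with a stated time of 72 h (on this read-out higher numbers stand for weaker inhibition of growth and lower numbers for stronger inhibition of growth), compound 3 gives the lowest of the two numbers; compound 1 sits within the scatter of it, so no order between the two is claimed. Compound 2 gives only a limit. For the measured compounds named here, the one measured step is an at least 3.8-fold lower number from compound 2 to compound 3 (0.58 log units; beyond the scatter), a change of the whole five-membered ring.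

Compound 4 `COc1ccc(CNC(=O)/C(C#N)=C/c2ccc(-c3ccccc3)o2)cc1` differs from compound 3 by phenyl in place of chloro on an aromatic carbon. Going by the values given here, no measured step swaps one substituent for another on the same ring, so the step from compound 3 has no direct precedent; the expectation is therefore no change beyond the scatter. Compound 4 is estimated at 11000 nM, with a range from 3000 nM to 40000 nM. This estimate means an expected step of a 1.2-fold lower number from compound 3 to compound 4 (0.07 log units; within the scatter).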

Compound 4, concentration for 50% growth inhibition: > 100000 nM
Compound 4 ended at the assay's limit (the forecaster's own chance of this, stated with the estimate: 10%); middle value at least 9.0-fold (0.95 log units) away from the limit.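

In this assay the aromatic carbon next to the ring oxygen proves sensitive to its substituent, as phenyl in place of chloro weakens inhibition of growth (an at least 7.6-fold higher number from compound 3 to compound 4 (0.88 log units; beyond the scatter)). The earlier step exchanged the whole five-membered ring, whereas this one changes a single substituent on that ring and leaves the rest of the molecule untouched. Compound 4 gives a limit of the assay, not a number: the limit of > 100000 nM in this assay, at which 1 of the 4 values shown sits.

The compounds shown leave open whether the loss is specific to phenyl. Methyl, an amine or a carboxylic acid at this carbon would show whether any group other than chloro keeps measurable inhibition of growth.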